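The source may report more compounds than this note shows. Statements on the series, on what has been measured and on what is new or still open speak of the compounds shown alone.

Measured so far, in an assay on cells for inhibition of cytochrome P450 11B2, mitochondrial (Homo sapiens), read by HTRF, with stated times of 1 h and 3 h; a higher number here means a weaker inhibitor, a lower number a stronger inhibitor:
compound 1 `Cc1nn(-c2cncc(C(C)(C)O)c2)c2ccccc12` gives 33.5 nM
compound 2 `CC(C)(O)c1cncc(-n2nc(C(F)(F)F)c3ccccc32)c1` gives 300 nM
compound 3 `Cc1ccc2c(cnn2-c2cncc(C(C)(C)O)c2)c1` gives 97.9 nM

Within the data shown here, the one counted change among them, (trifluoromethyl in place of methyl on an aromatic carbon), produced a 9.0-fold higher number from compound 1 to compound 2 (0.95 log units; beyond the scatter). Compound 3 has the same atoms as compound 1 joined differently; the difference between the two cores is not broken down here.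

Compound 4 `CC(C)(O)c1cncc(-n2ncc3cc(C(F)(F)F)ccc32)c1` is not yet measured. It differs from compound 3 by trifluoromethyl in place of methyl on an aromatic carbon. This is the same kind of change as from compound 1 to compound 2, but at a different place: in compound 2 it sits on a five-membered aromatic ring with 2 nitrogen, next to the ring nitrogen, whereas in compound 4 it sits on a six-membered aromatic ring of carbon only, meta to a fused ring and para to a fused ring. Among the measured compounds shown here, the only precedent is the step in this assay from compound 1 to compound 2, a 9.0-fold higher number from compound 1 to compound 2 (0.95 log units; beyond the scatter), so compound 4 is expected to be weaker than compound 3, with the step estimated at a 3.1-fold higher number from compound 3 to compound 4 (0.49 log units; beyond the scatter) and held smaller than that precedent. The place of the change differs, and no change at that place has been measured here. The estimate for compound 4 is 300 nM, expected between 100 nM and 900 nM.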

Compound 4, half-maximal inhibitory concentration: 507 nM
Compound 4: the middle estimate sits 1.7-fold (0.23 log units) below what was measured; low and high end bracket the measured number.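

In this assay, trifluoromethyl in place of methyl on an aromatic carbon weakens inhibition on both cores, with a 5.2-fold higher number from compound 3 to compound 4 (0.71 log units; beyond the scatter). The two steps do not differ beyond the scatter, so in these two pairs the change carries over from one core to the other at a similar size, although it sits at a different place on each: the same change on two cores in this assay, a 9.0-fold higher number (0.95 log units; beyond the scatter) from compound 1 to compound 2 and a 5.2-fold higher number (0.71 log units; beyond the scatter) from compound 3 to compound 4, 1.7-fold (0.24 log units) apart, within the scatter of two such steps. Two pairs do not give a rule for other cores or other places, and they do not show why the number rises.

The compounds shown leave open how other groups, such as a chlorine atom, a nitrile or an amine, would read at these two places. Also open, on these data alone, is how methyl and trifluoromethyl would compare on the other carbons of the six-membered aromatic ring.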